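Swapping a flexible ether chain for a phenyl ring

A few compounds are considered here, and "the series" means these few. Any claim that something is new, unique, unknown or untested is made for them only; others in the source may bear on it.

Measured so far:
compound 1, `CCOCCOc1nc(-c2ccc(C(=O)O)cc2)sc1C`: 15.1 nM
compound 2, `Cc1sc(-c2ccc(C(=O)O)cc2)nc1-c1ccc2c(c1)C(C)(C)CCC2(C)C`: 8.2 nM

Both measured compounds share the same core and differ only in the group attached to it. In an assay on isolated protein with retinoic acid receptor alpha (Homo sapiens) as the target, read by TR-FRET, with a stated time of 4 h (a higher number here means that more compound is needed for the effect, a lower number that less compound is needed), compound 1 gives 15.1 nM, while compound 2 gives 8.2 nM. Of the two numbers, compound 1 has the higher one, but the gap to compound 2 lies within the usual scatter of repeated measurements, so the two cannot be told apart on this evidence.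

Compound 3, `Cc1sc(-c2ccc(C(=O)O)cc2)nc1-c1ccccc1`, has not yet been measured. Relative to compound 1 the change is phenyl in place of 2-ethoxyethoxy on an aromatic carbon. The new group is a plain aromatic ring in place of a chain carrying two oxygens.

Because compound 2 gives 8.2 nM with a ring system at the same place and compound 1 gives 15.1 nM with a chain there, the nature of this group appears to matter little among the compounds shown. For compound 3 no step beyond the scatter is expected, with a slight lean toward a lower number: the expected step is a 1.4-fold lower number from compound 1 to compound 3 (0.14 log units; within the scatter). Compound 3 is therefore estimated at 11 nM, in the range 4 nM to 35 nM.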

Compound 3, half-maximal effective concentration: 77.5 nM
Compound 3: middle estimate off by 7.0-fold (0.85 log units), on the low side; measured number outside the range, above it.
By their numbers in this assay, from the lowest: compounds 2 and 1 (each within the scatter of the next); then compound 3.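

In this assay, the step of a 5.1-fold higher number from compound 1 to compound 3 (0.71 log units; beyond the scatter) shows that this position, on an aromatic carbon next to the ring nitrogen, does respond to the group placed there, even though 2-ethoxyethoxy and phenyl have the same count of heavy atoms. Having a ring at this place does not by itself keep the number low: compound 2, with its larger ring system, gives 8.2 nM, while compound 3, with a plain phenyl, gives 77.5 nM. No accompanying measurement speaks to what lies behind this step.

The compounds shown leave open whether the step goes with the loss of the two oxygens of the chain, the loss of the chain itself, or the arrival of an aromatic ring, as all of these happen together in this one change. A hexyl chain, made of carbon and hydrogen only, or a pyridine ring at the same place would help to pull these apart.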